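Swapping fluoro for chloro on a bis-furan amidine

The compounds below may be only part of what the source reports. "The series", "measured", "known", "first", "only" and "open" are said of these compounds alone.

Measured compounds:
- compound 1, `N=C(N)c1ccc(-c2ccc(-c3cncc4ccccc34)s2)s1`: 1610 nM
- compound 2, `N=C(N)c1ccc(-c2ccc(-c3ccc(F)cc3)o2)o1`: 1180 nM

Of the compounds shown here, two have been measured in a functional assay on HCT-116 cells (Homo sapiens) for inhibition, read by sulforhodamine B assay, with a stated time of 48 h; on this read-out higher numbers stand for weaker inhibition of growth and lower numbers for stronger inhibition of growth. Compound 1 carries a bicyclic nitrogen-containing aromatic group on a bis-thiophene core, and in this assay compound 1 gives 1610 nM. Compound 2 carries a fluoro-substituted phenyl group on a bis-furan core, and in this assay compound 2 gives 1180 nM. Compound 2 has the lower of the two numbers, but the gap to compound 1 lies within the usual scatter, so the two cannot be told apart on these data.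

The next compound, compound 3, `N=C(N)c1ccc(-c2ccc(-c3ccc(Cl)cc3)o2)o1`, differs from compound 2 in one place: chloro in place of fluoro on an aromatic carbon. For the measured compounds named here, no measured pair in this set shows what such a swap does, so there is no step to lean on. With compound 2 at 1180 nM as the only anchor, the step from compound 2 to compound 3 is expected to be small, with no clear direction beyond the scatter, a 1.2-fold lower number from compound 2 to compound 3 (0.09 log units; within the scatter). Compound 3 is therefore estimated at 950 nM in this assay, within a range from 350 nM to 2600 nM.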

Compound 3, concentration for 50% growth inhibition: 1900 nM
The estimate for compound 3 lay 2.0-fold (0.30 log units) below the measured number, within the range that was stated.
By their numbers in this assay, from the lowest: compounds 2, 1 and 3 (each within the scatter of the next).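

In this assay chloro in place of fluoro on an aromatic carbon, para to a large group, is read as a 1.6-fold higher number from compound 2 to compound 3 (0.21 log units; within the scatter) and so gives no difference that can be separated from the ordinary variation between repeat measurements. For the compounds shown here, this is the first direct comparison in the set at this position, and it shows that, on these data, compound 2 and compound 3 cannot be told apart, so neither halogen can be preferred here. Nothing available explains the result or links it to any property of either group.

From the compounds shown here alone, what remains open is whether this position can affect growth inhibition at all, since a swap between two halogens tests only a narrow change: a methoxy group, a nitrile, an amine or a carboxylic acid in the same place might give a step beyond the scatter, or might not. Going by these compounds alone, it is also unknown whether the same swap would give a similar result on a different core, such as the one in compound 1, because a single pair cannot show whether its outcome carries over to other compounds.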